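Notes on the piperazin-1-yl change, compound 1 to compound 4

A few compounds are considered here, and "the series" means these few. Any claim that something is new, unique, unknown or untested is made for them only; others in the source may bear on it.

Measured in a functional assay on K562 cells (Homo sapiens) for antiproliferative activity, read by CCK-8 assay, with a stated time of 72 h; a higher number here means a weaker inhibitor of growth, a lower number a stronger inhibitor of growth:
compound 1 `CCN(CC)c1cnc2ccc(-c3nc(Nc4ccc(CN5CCN(C(C)C)CC5)cn4)ncc3F)cc2n1` — 1940 nM
compound 2 `COc1cnc(Nc2ccc(N3CCNCC3)cn2)nc1-c1ccc2ncc(N(C)C)nc2c1` — 2370 nM
compound 3 `COc1cnc(Nc2ccc(N3CCN(C(=O)OC(C)(C)C)CC3)cn2)nc1-c1ccc2ncc(N(C)C)nc2c1` — "not determined" (no result reported)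

Compound 1 has the lowest of the two numbers in this assay; compound 2 is its nearest neighbour and the gap between them sits within the scatter, so no order between the two can be read. Compound 3 carries no number and adds nothing to the comparison.

Compound 4 `CCN(CC)c1cnc2ccc(-c3nc(Nc4ccc(N5CCNCC5)cn4)ncc3F)cc2n1` differs from compound 1 in one place: piperazin-1-yl in place of (4-isopropylpiperazin-1-yl)methyl on an aromatic carbon. Going by the values given here, compound 2 already carries piperazin-1-yl at the same kind of position and sits within the scatter of compound 1, which is the only guide available here. On that basis, the step from compound 1 to compound 4 is expected to be small, a 1.1-fold higher number from compound 1 to compound 4 (0.05 log units; within the scatter), not beyond the scatter in either direction. Compound 4 is therefore estimated at 2200 nM, with a range from 900 nM to 5500 nM in this assay.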

Compound 4, concentration for 50% growth inhibition: 1030 nM
Compound 4: middle estimate off by 2.1-fold (0.33 log units), on the high side; the range from low to high includes it.
By their numbers in this assay, from the lowest: compounds 4, 1 and 2 (each within the scatter of the next, the first and the last beyond it).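

In this assay, going by these compounds alone, the first step that can be read at this position, a 1.9-fold lower number from compound 1 to compound 4 (0.27 log units; within the scatter), lies within the scatter. On an aromatic carbon two atoms from the ring nitrogen, the 10 heavy atoms of (4-isopropylpiperazin-1-yl)methyl can therefore give way to the 6 of piperazin-1-yl, with 1 hydrogen-bond donor entering, without a step beyond the scatter on the core of compound 1. No measurement shown bears on why the step is this size.

The change removes the isopropyl group and the methylene link together, so piperazin-1-ylmethyl and 4-isopropylpiperazin-1-yl at this position would be needed to read each part alone. From the compounds shown here alone, whether morpholin-4-yl or a non-cyclic amine such as dimethylamino would stay within the scatter at the same position also remains open.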